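Para-substituent swap on the amino-thioxo core series

The source may hold more compounds than are shown below. What is called first, only, known or untested is meant among the compounds shown, and "the series" means these compounds.

Measured compounds:
compound 1 `CCC(C)Sc1nc2c(cc(-c3ccc(Cl)cc3)n2-c2ccccc2)c(=N)s1` 2%
compound 2 `CCC(C)Sc1nc2c(cc(-c3ccc(C)cc3)n2-c2ccccc2)c(=N)s1` 2%
compound 3 `N=c1c2cc(-c3ccc(Cl)cc3)n(-c3ccccc3)c2[nH]c(=S)n1N` 0%

In a functional assay on the whole organism for inhibition, with Rattus norvegicus as the target, read by ELISA, with stated times of 30 min and 6 h, at a dose of 30 mg/kg by the oral route (a higher number here means more inhibition at the dose given (going by the name of the read-out), a lower number less inhibition), compound 1 gives 2% and compound 2 gives 2%. The difference between them is methyl in place of chloro on an aromatic carbon and the step is no change at the digits printed from compound 1 to compound 2 (within the scatter). Compound 3 carries a different core; how its core differs from that of compound 1 is not broken down here. In this assay compound 3 gives 0%, which sits within the scatter of both compound 1 and compound 2, so no order among the three can be read.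

Compound 4 `Cc1ccc(-c2cc3c(=N)n(N)c(=S)[nH]c3n2-c2ccccc2)cc1` has not yet been measured. It differs from compound 3 by methyl in place of chloro on an aromatic carbon, the same change as that from compound 1 to compound 2, made on the other core. Since the earlier step was no change at the digits printed from compound 1 to compound 2 (within the scatter), the step from compound 3 to compound 4 is expected to be a number 2 percentage points higher from compound 3 to compound 4 (within the scatter), resting only on that one precedent and on the low read-out of compound 3. Compound 4 is therefore estimated to give 2% in this assay, with a range from -6% to 10%.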

Compound 4, a percentage reported as inhibition, in the whole organism at one dose (the size of the read-out at that dose, not a potency): 0%
Compound 4: the middle estimate sits 2 percentage points above what was measured; measured number inside the range.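

In this assay, going from 4-chlorophenyl to 4-methylphenyl on the core of compound 3 gives no change at the digits printed from compound 3 to compound 4 (within the scatter). Set beside the earlier step on the core of compound 1, the change carries across the two cores with no visible difference: the same change on two cores in this assay, no change at the digits printed (within the scatter) from compound 1 to compound 2 and no change at the digits printed (within the scatter) from compound 3 to compound 4, 0 percentage points apart, within the scatter of two such steps

Among the compounds shown here, all four read-outs sit near the bottom of the scale, so this agreement shows only that the change brings no detectable inhibition on either core at this single dose; it does not show that the change would stay neutral on a compound with a clear read-out, and it gives no measure of potency.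

The compounds shown leave open whether another group at the same place, such as an amine, a carboxylic acid or a methoxy group, would lift the read-out on either core. Also open, as far as these compounds go, is whether a longer chain on the sulfur of the core of compound 1 would change the picture.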